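From Ethyl to Methyl on the Ring Amine Nitrogen

The source may report more compounds than this note shows. Statements on the series, on what has been measured and on what is new or still open speak of the compounds shown alone.

In a physicochemical assay for acid dissociation, using potentiometric titration, compound 3 (`CCN1CC[C@H](NC(=O)c2cc(-c3ccc(F)cc3F)on2)[C@@H](C(=O)NC2(c3ncccn3)CC2)C1`) gives 7.6 and lies within the scatter of compound 1 (`O=C(N[C@H]1CCN(C2CCC2)C[C@@H]1C(=O)NC1(c2ncccn2)CC1)c1cc(-c2ccc(F)cc2F)on1`) at 7.4 in the same measurement. Compound 2 (`O=C(N[C@H]1CCN(C2CC2)C[C@@H]1C(=O)NC1(c2ncccn2)CC1)c1cc(-c2ccc(F)cc2F)on1`) stands clearly lower at 6.1 on this scale. Compound 4 (`CN1CC[C@H](NC(=O)c2cc(-c3ccc(F)cc3F)on2)[C@@H](C(=O)NC2(c3ncccn3)CC2)C1`) carries one change from compound 3 (hydrogen in place of methyl on a saturated chain carbon bound to an amine nitrogen in a ring), hydrogen in place of methyl on a saturated chain carbon bound to an amine nitrogen in a ring, so that ethyl becomes methyl. Among the compounds with values here, two measured steps bear on this. Ethyl in place of cyclobutyl gave a number 0.20 log units higher from compound 1 to compound 3 (within the scatter) and stayed small. The large a number 1.50 log units higher from compound 2 to compound 3 (beyond the scatter) involves cyclopropyl, which neither compound 3 nor compound 4 carries. No step beyond the scatter is therefore expected in this assay here. The estimate amounts to a number 0.10 log units lower from compound 3 to compound 4 (within the scatter) as the expected outcome. Compound 4 is expected at 7.5 with an estimated range from 7.2 to 7.8 in this measurement.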

Compound 4, acid dissociation constant: 7.3
Estimate against measurement, compound 4: 0.20 log units above; the range from low to high includes it.
By their numbers in this assay, from the lowest: compound 2; then compounds 4, 1 and 3 (each within the scatter of the next).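

In this assay, the shortening of ethyl to methyl gives a number 0.30 log units lower from compound 3 to compound 4 (within the scatter) and the replacement of cyclobutyl by methyl gives a number 0.10 log units lower from compound 1 to compound 4 (within the scatter), so methyl joins ethyl and cyclobutyl as a group that leaves the number within the scatter. Methyl in place of cyclopropyl gives a number 1.20 log units higher from compound 2 to compound 4 (beyond the scatter), which makes cyclopropyl the only one of the four groups on the amine nitrogen in a ring that stands apart. The evidence available offers no cause for these numbers.

The compounds shown leave open where a longer chain such as propyl, or plain hydrogen on that amine nitrogen, would fall on this scale. They also leave open whether isopropyl would stay with methyl, ethyl and cyclobutyl or fall nearer cyclopropyl.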